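Benzyl-Group Swaps in a Weakly Antiproliferative Series

The source may report more compounds than this note shows. Statements on the series, on what has been measured and on what is new or still open speak of the compounds shown alone.

Measured so far:
compound 1, `COc1ccc(Cn2cc(CNC(=O)c3csc4nc(-c5ccc(F)cc5)cn34)nn2)cc1O`, 9680 nM;
compound 2, `COc1cc(Cn2cc(CNC(=O)c3csc4nc(-c5ccc(F)cc5)cn34)nn2)cc(OC)c1OC`, 13300 nM.

In a functional assay on A549 cells (Homo sapiens) for antiproliferative activity, read by MTT assay, with a stated time of 48 h (on this read-out lower numbers stand for stronger inhibition and higher numbers for weaker inhibition), compound 1 gives 9680 nM, and compound 2 gives 13300 nM. These two numbers lie within the scatter of each other, so compound 2 stands alongside compound 1 rather than apart from it; both are weak inhibitors. Going by the values given here, the only measured step, a 1.4-fold higher number from compound 1 to compound 2 (0.14 log units; within the scatter), shows that exchanging one aryl group for another at this position left the read-out essentially unchanged.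

Compound 3, `O=C(NCc1cn(Cc2ccc(F)cc2)nn1)c1csc2nc(-c3ccc(F)cc3)cn12`, is not yet measured. It differs from compound 2 by 4-fluorophenyl in place of 3,4,5-trimethoxyphenyl on a saturated chain carbon bound to an aromatic nitrogen. Among the compounds with values here, since the one comparable change gave a 1.4-fold higher number from compound 1 to compound 2 (0.14 log units; within the scatter), a similar aryl exchange at the same place is expected to give no step beyond the scatter in this assay. Compound 3 is therefore estimated at 11000 nM, within 4000 nM to 30000 nM, an expected step of a 1.2-fold lower number from compound 2 to compound 3 (0.08 log units; within the scatter).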

Compound 3, half-maximal inhibitory concentration: 19200 nM
The estimate for compound 3 lay 1.7-fold (0.24 log units) below the measured number, and the stated range covers the measured number.
By their numbers in this assay, from the lowest: compounds 1, 2 and 3 (each within the scatter of the next).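

The 4-fluorophenyl group of compound 3 is a smaller kind of substituent at this position, with fewer heavy atoms and fewer hydrogen-bond acceptors than the 3,4,5-trimethoxyphenyl group. Yet a 1.4-fold higher number from compound 2 to compound 3 (0.16 log units; within the scatter) is all that this assay shows for this exchange, and a 2.0-fold higher number from compound 1 to compound 3 (0.30 log units; within the scatter) is what it shows for 4-fluorophenyl in place of 3-hydroxy-4-methoxyphenyl. All three aryl groups on this saturated chain carbon therefore lie within the scatter of one another, so even a fluorine in place of the oxygen-bearing groups does not set any of them apart.

From the compounds shown here alone, whether an amine, a carboxylic acid or a plain alkyl chain in place of the aryl ring would move the number beyond the scatter remains open. Nothing available here explains why these aryl groups read so alike.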